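This account rests on a few compounds, and the source may have more. Where it says the series, first, only, none or still open, it means among the compounds named here.

Among the compounds with values here, in a functional assay on MCF7 cells (Homo sapiens) for cytotoxicity, read by MTT assay, with a stated time of 48 h (on this read-out lower numbers stand for stronger inhibition and higher numbers for weaker inhibition), compound 1 `Cc1ccccc1-c1nnc(SCCn2c([N+](=O)[O-])cnc2C)o1` gives 15800 nM and compound 2 `Cc1ncc([N+](=O)[O-])n1CCSc1nnc(-c2ccccc2N)o1` gives 20100 nM, so compound 2 sits within the scatter of the only other number available. The next compound, compound 3 `Cc1ncc([N+](=O)[O-])n1CCSc1nnc(-c2ccc(N)cc2)o1`, has the same atoms as compound 2, joined differently: 4-aminophenyl in place of 2-aminophenyl on an aromatic carbon. Put briefly, this is 4-aminophenyl in place of 2-aminophenyl on an aromatic carbon. Within the data shown here, only one measured step bears on this change, and only loosely, as it places amino where methyl stood rather than moving the amino group: a 1.3-fold higher number from compound 1 to compound 2 (0.10 log units; within the scatter). Among the measured compounds shown here, on that small step, no change beyond the scatter is expected in this assay, and no direction is favoured, although the data include no direct precedent. The expected step is a 1.1-fold lower number from compound 2 to compound 3 (0.05 log units; within the scatter). For compound 3 the estimated value is 18000 nM, with an expected range of 8000 nM to 40000 nM.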

Compound 3, half-maximal inhibitory concentration: 19800 nM
For compound 3 the middle estimate is 1.1-fold (0.04 log units) below the measured one, and the stated range covers the measured number.
By their numbers in this assay, from the lowest: compounds 1, 3 and 2 (each within the scatter of the next).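

Within the data shown here, the step of a 1.0-fold lower number from compound 2 to compound 3 (0.01 log units; within the scatter) in this assay is the first direct reading of where the amino group stands on the phenyl ring, and 4-aminophenyl in place of 2-aminophenyl leaves the number within the scatter. The step of a 1.3-fold higher number from compound 1 to compound 3 (0.10 log units; within the scatter), with 4-aminophenyl in place of 2-methylphenyl, also lies within the scatter, so compounds 1, 2 and 3 cannot be told apart in this cell read-out, whichever of these groups sits on the ring. Nothing available explains why these changes leave the number within the scatter.

Going by these compounds, it remains open whether a carboxylic acid or a trifluoromethyl group on the phenyl ring, or an unsubstituted phenyl ring, would move the number beyond the scatter. A longer chain in the link of the shared core is equally untested by the compounds shown here.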